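Swapping a Dichlorophenyl for a Hydroxyphenyl Group

The source may hold more compounds than are shown below. What is called first, only, known or untested is meant among the compounds shown, and "the series" means these compounds.

Compound 1 `CC/C(=C(/c1ccc(NC(=O)C(C)C)cc1)c1ccc(OC)cc1)c1ccc(O)cc1` gives 13600 nM 
Compound 2 `CC/C(=C(\c1ccccc1)c1ccc(NC(=O)C(C)C)cc1)c1ccc(Cl)cc1Cl` gives 8300 nM 

Both compounds were tested in a functional assay on MCF7 cells (Homo sapiens) for inhibition, read by trypan blue exclusion, with a stated time of 72 h (on this read-out lower numbers stand for stronger inhibition of growth and higher numbers for weaker inhibition of growth), and their two values lie within the usual scatter of each other, so compound 2 stands level with compound 1 on these numbers. Compound 3 `CC/C(=C(\c1ccccc1)c1ccc(NC(=O)C(C)C)cc1)c1ccc(O)cc1` differs from compound 2 in one place: 4-hydroxyphenyl in place of 2,4-dichlorophenyl on a double-bonded chain carbon bound to a double-bonded chain carbon and a saturated chain carbon. For the measured compounds named here, no measured pair shows this swap directly. Compound 1 also carries a 4-hydroxyphenyl group and gives 13600 nM, which is level with compound 2. No step beyond the scatter is therefore expected in this assay, and the expected change is a 1.2-fold higher number from compound 2 to compound 3 (0.08 log units; within the scatter), with no clear direction. Compound 3 is estimated at 10000 nM, with an expected range from 4000 nM to 25000 nM for repeated measurements.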

Compound 3, concentration for 50% growth inhibition: 8100 nM
The estimate for compound 3 lay 1.2-fold (0.09 log units) above the measured number, within the range that was stated.
By their numbers in this assay, from the lowest: compounds 3, 2 and 1 (each within the scatter of the next).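

In this assay, the direct pair shows that 4-hydroxyphenyl can stand in place of 2,4-dichlorophenyl at this double-bonded chain carbon with no step beyond the scatter (a 1.0-fold lower number from compound 2 to compound 3 (0.01 log units; within the scatter)). The second single change, hydrogen in place of methoxy on an aromatic carbon, also stays within the scatter (a 1.7-fold lower number from compound 1 to compound 3 (0.23 log units; within the scatter)), so neither swap separates these compounds on this read-out. No measurement here bears on why these changes leave the numbers level.

All three compounds lie within the scatter of their neighbours, so neither change yet marks a group that matters for growth inhibition. From the compounds shown here alone, whether an amine or a carboxylic acid at this position would move the number beyond the scatter remains open.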